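A few compounds are considered here, and "the series" means these few. Any claim that something is new, unique, unknown or untested is made for them only; others in the source may bear on it.

Measured compounds:
- compound 1 `Cc1ccc(Cl)cc1Nc1nc(C(F)(F)F)ccc1CNC(=O)C(C)c1ccc(NS(C)(=O)=O)c(F)c1`: 140 nM
- compound 2 `CC(C(=O)NCc1ccc(C(F)(F)F)nc1N1CCC(C(F)(F)F)CC1)c1ccc(NS(C)(=O)=O)c(F)c1`: 31 nM

Within the data shown here, in a functional assay on CHO-K1 cells for antagonist activity at transient receptor potential cation channel subfamily V member 1 (Homo sapiens), read by FLIPR (a lower number here means a stronger inhibitor, a higher number a weaker inhibitor), compound 1 gives 140 nM, the highest of the two numbers so far; its nearest neighbour is compound 2, which in this assay gives 31 nM. Among the measured compounds shown here, the one measured step, a 4.5-fold lower number from compound 1 to compound 2 (0.65 log units; beyond the scatter), replaces the (5-chloro-2-methylphenyl)amino group with 4-(trifluoromethyl)piperidin-1-yl on the shared core.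

Compound 3 `CC(C(=O)NCc1ccc(C(F)(F)F)nc1N1CCC(CN(C)C)CC1)c1ccc(NS(C)(=O)=O)c(F)c1` has not been measured. It differs from compound 1 by 4-((dimethylamino)methyl)piperidin-1-yl in place of (5-chloro-2-methylphenyl)amino on an aromatic carbon. This is the same exchange of an arylamino group for a piperidin-1-yl ring as in the measured step, so that step bears directly on it, but the substituent on the ring is not the same, so a step of reduced size toward a lower number is expected: a 2.3-fold lower number from compound 1 to compound 3 (0.37 log units; beyond the scatter). In this assay compound 3 is therefore estimated at 60 nM, with a range from 20 nM to 200 nM.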

Compound 3, half-maximal inhibitory concentration: 426 nM
Compound 3: the middle estimate sits 7.1-fold (0.85 log units) below what was measured; the whole stated range lies below it.
By their numbers in this assay, from the lowest: compound 2; then compound 1; then compound 3.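

In this assay, replacing (5-chloro-2-methylphenyl)amino with a piperidin-1-yl ring does not by itself give a lower number: a 3.0-fold higher number from compound 1 to compound 3 (0.48 log units; beyond the scatter) runs in the opposite direction to a 4.5-fold lower number from compound 1 to compound 2 (0.65 log units; beyond the scatter) on the same aromatic carbon. With the ring held constant, the substituent on its saturated carbon decides the outcome, as (dimethylamino)methyl in place of trifluoromethyl gives a 14-fold higher number from compound 2 to compound 3 (1.14 log units; beyond the scatter) in the largest step of the set. No measurement here accounts for this difference between the two ring substituents.

The compounds shown do not separate the contribution of the dimethylamino nitrogen from that of the methylene carrying it. A methyl, methoxymethyl or isopropyl group on the same ring carbon would test whether the higher number follows the amine or extends to other groups in that place.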